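A few compounds are considered here, and "the series" means these few. Any claim that something is new, unique, unknown or untested is made for them only; others in the source may bear on it.

Among the compounds with values here, in a functional assay on DU-145 cells (Homo sapiens) for inhibition, read by MTT assay, with stated times of 18 h and 4 h (on this read-out lower numbers stand for stronger inhibition and higher numbers for weaker inhibition), compound 1 `CCCCCCCCCCOP(=O)(O)OCCSC(=S)N1CCCCCC1` gives 24000 nM, the only true number among the three compounds measured. Compound 2 `CCCCCCCCOP(=O)(O)OCCSC(=S)N1CCCCC1` reaches only a limit, > 100000 nM. Compound 3 `CCCCCCCCOP(=O)(O)OCCSC(=S)N1CCN(C)CC1` is also known only as a limit, > 100000 nM. It therefore has no number of its own and sits on (the limit of > 100000 nM in this assay, at which 2 of the 3 values shown sit).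

Compound 4 `CCCCCCCCOP(=O)(O)OCCSC(=S)N1CCCCCC1` departs from compound 3 by a single change, azepan-1-yl in place of 4-methylpiperazin-1-yl on a thiocarbonyl carbon. Within the data shown here, the one measured step at this place is a step that the two limits leave unreadable from compound 2 to compound 3, so it offers no size to carry over. Among the measured compounds shown here, the only guide left is compound 1, which bears the same azepan-1-yl and gives 24000 nM in this assay. A move toward stronger inhibition is thus expected, though its size is poorly defined, and a further limit in this assay would be no surprise. The estimate for the change is an at least 1.6-fold lower number from compound 3 to compound 4 (0.22 log units; that floor lies within the scatter). For compound 4 the estimated value is 60000 nM, with an expected range from 25000 nM to 150000 nM.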

Compound 4, half-maximal inhibitory concentration: 59100 nM
Beside the measured number, compound 4's estimate is 1.0-fold (0.01 log units) above it; low and high end bracket the measured number.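

Within the data shown here, with compound 4, azepan-1-yl on the thiocarbonyl carbon gives the first true number on this shorter chain, while the piperidin-1-yl compound 2 and the 4-methylpiperazin-1-yl compound 3 remain limits and not numbers: the limit of > 100000 nM in this assay, at which 2 of the 4 values shown sit. In this assay the ring change reads as an at least 1.6-fold lower number from compound 3 to compound 4 (0.22 log units; that floor lies within the scatter) and as an at least 1.6-fold lower number from compound 2 to compound 4 (0.22 log units; that floor lies within the scatter), so these are only floors that do not yet clear the scatter, and the step between the two limits cannot be read. With azepan-1-yl held fixed, hydrogen in place of ethyl on a saturated chain carbon gives a 2.5-fold higher number from compound 1 to compound 4 (0.39 log units; beyond the scatter), a modest step that does lie beyond the scatter.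

On these data alone, it remains open whether morpholin-4-yl or an open-chain amine such as diethylamino on the thiocarbonyl carbon would give a true number on this shorter chain, and how either would compare with azepan-1-yl. As far as these compounds go, it also remains open whether a longer chain would bring the piperidin-1-yl or 4-methylpiperazin-1-yl compounds within reach of a true number, as the azepan-1-yl pair might suggest.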